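Swapping the Amide Aryl Group: Methyl to Chloro

The compounds below may be only part of what the source reports. "The series", "measured", "known", "first", "only" and "open" are said of these compounds alone.

Measured so far:
compound 1, `COc1ccc2c(=O)c(/C=C/C(=O)NCc3ccc(F)cc3)coc2c1`, 7960 nM
compound 2, `COc1ccc2c(=O)c(/C=C/C(=O)Nc3ccccc3OC)coc2c1`, 17600 nM
compound 3, `COc1ccc2c(=O)c(/C=C/C(=O)Nc3ccccc3C)coc2c1`, 22500 nM

All three share one core and differ only in the group on the amide-type nitrogen. In a functional assay (QGY7701 cells, Homo sapiens) for inhibition, read by MTT assay, with a stated time of 48 h (a lower number here means a stronger inhibitor, a higher number a weaker inhibitor), compound 3 has the highest number of the three. The gap to compound 2 is within the scatter (a 1.3-fold higher number from compound 2 to compound 3 (0.11 log units; within the scatter)), so the two cannot be told apart; compound 1, with its 4-fluorobenzyl group, gives a clearly lower number (a 2.8-fold higher number from compound 1 to compound 3 (0.45 log units; beyond the scatter), and likewise a 2.2-fold higher number from compound 1 to compound 2 (0.34 log units; beyond the scatter)).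

Compound 4, `COc1ccc2c(=O)c(/C=C/C(=O)Nc3ccc(Cl)cc3)coc2c1`, is the next step: 4-chlorophenyl in place of 2-methylphenyl on an amide-type nitrogen. Among the measured compounds shown here, no measured step tests a chlorine or a substituent at that position of the phenyl ring. For the measured compounds named here, the only step that swaps a substituent on the phenyl ring, from compound 2 to compound 3, stayed within the scatter, and both aryl amides sit close together. The expectation for compound 4 in this assay is therefore a change of a 1.3-fold lower number from compound 3 to compound 4 (0.10 log units; within the scatter), that is, nothing beyond the scatter. The estimated value for compound 4 is 18000 nM, within a range from 7000 nM to 45000 nM.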

Compound 4, half-maximal inhibitory concentration: > 100000 nM
Compound 4: a limit, no number (the forecaster's own chance of this, stated with the estimate: 5%); at least 5.5-fold (0.74 log units) between middle value and limit.
By their numbers in this assay, from the lowest: compound 1; then compounds 2 and 3 (each within the scatter of the next). At a limit, above all of these: compound 4.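

Compound 4 stands at a limit, not a number: the limit of > 100000 nM in this assay, at which 1 of the 4 values shown sits.

In this assay, putting 4-chlorophenyl on the amide-type nitrogen gives an at least 4.4-fold higher number from compound 3 to compound 4 (0.64 log units; beyond the scatter), an at least 5.6-fold higher number from compound 2 to compound 4 (0.75 log units; beyond the scatter) and an at least 12-fold higher number from compound 1 to compound 4 (1.09 log units; beyond the scatter). The only earlier change to a substituent on the phenyl ring, methoxy to methyl, stayed within the scatter, so this is the first sign among these compounds that the aryl amides are not interchangeable.

Compound 4 differs from compound 3 both in the substituent and in its place on the ring, so the compounds shown cannot say which of the two matters. Going by these compounds, how an amine or a carboxylic acid would behave on the phenyl ring in place of the chlorine also remains open.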